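Moving the methyl group on the benzyl amide

This account rests on a few compounds, and the source may have more. Where it says the series, first, only, none or still open, it means among the compounds named here.

Measured in a functional assay on L6 cells (Rattus norvegicus) for inhibition; on this read-out higher numbers stand for weaker inhibition and lower numbers for stronger inhibition:
- compound 1 `CC(C)c1c(C(=O)NCC2CCCCC2)nn(-c2ccc(F)cc2)c1OC[C@@H](O)C[C@@H](O)CC(=O)O`: "not determined" (no result reported)
- compound 2 `Cc1ccc(CN(C)C(=O)c2nn(-c3ccc(F)cc3)c(OC[C@@H](O)C[C@@H](O)CC(=O)O)c2C(C)C)cc1`: 1250 nM
- compound 3 `Cc1cccc(CNC(=O)c2nn(-c3ccc(F)cc3)c(OC[C@@H](O)C[C@@H](O)CC(=O)O)c2C(C)C)c1`: 280 nM

Among the compounds with values here, compound 3 has the lower of the two numbers available in this assay, and compound 2 is the only comparison, since compound 1 has no number. The next compound is compound 4 `Cc1ccccc1CNC(=O)c1nn(-c2ccc(F)cc2)c(OC[C@@H](O)C[C@@H](O)CC(=O)O)c1C(C)C`, where 2-methylphenyl stands in place of 3-methylphenyl on a saturated chain carbon bound to an amide-type nitrogen: 2-methylphenyl in place of 3-methylphenyl on a saturated chain carbon bound to an amide-type nitrogen.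

Within the data shown here, the only measured step is a 4.5-fold lower number from compound 2 to compound 3 (0.65 log units; beyond the scatter). That step changes more than the place of the methyl group, so it bears on this change only loosely. Among the measured compounds shown here, no measured pair isolates the 3-methylbenzyl to 2-methylbenzyl change, so the expectation starts from compound 3 at 280 nM, with a wide margin. The expected step is a 1.1-fold higher number from compound 3 to compound 4 (0.06 log units; within the scatter), a slight rise that is not expected to exceed the scatter. For compound 4, the estimated value is 320 nM, with an expected range of 120 nM to 850 nM.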

Compound 4, half-maximal inhibitory concentration: 2850 nM
Beside the measured number, compound 4's estimate is 8.9-fold (0.95 log units) below it; measured number outside the range, above it.
By their numbers in this assay, from the lowest: compound 3; then compound 2; then compound 4.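

In this assay, within the data shown here, with the same atoms joined differently, moving the methyl group from 3-methylbenzyl to 2-methylbenzyl gives a 10-fold higher number from compound 3 to compound 4 (1.01 log units; beyond the scatter), so the series responds strongly to where this one methyl group sits on the benzyl amide, which the earlier compounds could not show. The other comparison runs the opposite way to the earlier step from compound 2: replacing methyl(4-methylbenzyl)amino with (2-methylbenzyl)amino gives a 2.3-fold higher number from compound 2 to compound 4 (0.36 log units; beyond the scatter), so keeping the amide hydrogen does not by itself secure a lower number. Nothing available explains the effect of the methyl shift.

On these data alone, it remains open where unsubstituted benzyl and (4-methylbenzyl)amino with the amide hydrogen kept would fall relative to compound 3 and compound 4. As far as these compounds go, it is also open whether 2-fluorobenzyl or 2-methoxybenzyl would follow 2-methylbenzyl.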